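This account rests on a few compounds, and the source may have more. Where it says the series, first, only, none or still open, it means among the compounds named here.

In a functional assay on cells (T-cell line, Homo sapiens) for inhibition; on this read-out higher numbers stand for weaker inhibition and lower numbers for stronger inhibition:
- compound 1 `CCCN1CCC(COC(c2ccccc2)c2ccccc2)CC1`: 17800 nM
- compound 2 `CCCCCCCCCCN1CCC(COC(c2ccccc2)c2ccccc2)CC1`: 2600 nM
- compound 3 `C(#Cc1ccccc1)CN1CCC(COC(c2ccccc2)c2ccccc2)CC1`: not yet measured

Of the two measured compounds, compound 2 has the lower number and so the stronger inhibition. Compound 3 puts 2-phenylethynyl in place of nonyl on a saturated chain carbon bound to an amine nitrogen in a ring. Among the measured compounds shown here, only one measured step bears on this: a 6.8-fold lower number from compound 1 to compound 2 (0.84 log units; beyond the scatter), a modest gain on adding heptyl to the chain. For the measured compounds named here, no measured compound carries a ring on this chain, so the forecast is loose, but a modest rise in this assay is expected. The estimated step is a 2.3-fold higher number from compound 2 to compound 3 (0.36 log units; beyond the scatter). For compound 3 the expected value is 6000 nM, with an estimated range of 1800 nM to 20000 nM.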

Compound 3, half-maximal inhibitory concentration: > 20000 nM
Compound 3 gave a limit, no number; the forecaster's own chance of this, stated with the estimate: 5%; middle value at least 3.3-fold (0.52 log units) away from the limit.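

In this assay compound 3 gives only a limit, not a number: the limit of > 20000 nM in this assay, at which 1 of the 3 values shown sits.

Putting 2-phenylethynyl in place of nonyl weakens inhibition (an at least 7.6-fold higher number from compound 2 to compound 3 (0.88 log units; beyond the scatter)), so the gain seen with the long saturated chain does not carry over to this chain with its triple bond and aromatic ring. The other new step is a floor that lies within the scatter (an at least 1.1-fold higher number from compound 1 to compound 3 (0.05 log units; that floor lies within the scatter)), so it sets no order between these two compounds.

From the compounds shown here alone, whether the triple bond, the ring or both go with the weaker inhibition stays open. So does the outcome for a saturated chain ending in phenyl, such as 3-phenylpropyl, or for a chain longer than decyl.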